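The compounds below may be only part of what the source reports. "The series", "measured", "known", "first", "only" and "open" are said of these compounds alone.

Compound 1 `CCCCCCCC/C=C\CCCCCCC(=O)c1ncc(-c2ccoc2)o1` is one of two compounds that have so far been measured in an assay on isolated protein for inhibition of Fatty-acid amide hydrolase 1 (Homo sapiens); a higher number here means a weaker inhibitor, a lower number a stronger inhibitor. Compound 1 gives 610 nM, the higher of the two numbers. The other measured compound, compound 2 `CCCCCCCC/C=C\CCCCCCC(=O)c1ccncn1`, gives 110 nM in this assay, a lower number, and the gap between the two lies beyond the usual scatter. The two compounds differ in more than one place, so nothing can be said about any single change between them.

Compound 3 `CCCCCCCC/C=C\CCCCCCC(=O)c1ncc(-c2ccccc2)o1` has not yet been measured in this assay. It differs from compound 1 in one place: phenyl in place of furan-3-yl on an aromatic carbon. Within the data shown here, the data hold no comparable step between measured compounds, so the size of the change can only be estimated. Both groups are single aromatic rings, and the shared core and the long chain with its carbonyl remain unchanged. The expected step from compound 1 to compound 3 is therefore small, a 1.2-fold lower number from compound 1 to compound 3 (0.09 log units; within the scatter), in either direction and likely not beyond the scatter. Compound 3 is estimated to give 500 nM in this assay, within a range from 150 nM to 1500 nM.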

Compound 3, inhibition constant: 320 nM
Compound 3: middle estimate off by 1.6-fold (0.19 log units), on the high side; the range from low to high includes it.
By their numbers in this assay, from the lowest: compound 2; then compounds 3 and 1 (each within the scatter of the next).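

In this assay, phenyl in place of furan-3-yl on this aromatic carbon, next to the ring oxygen, gives a 1.9-fold lower number from compound 1 to compound 3 (0.28 log units; within the scatter) and so leaves the number within the scatter. Among these compounds, the first direct comparison at this position therefore cannot tell a six-membered aromatic ring of carbon only from a five-membered aromatic ring with 1 hetero atom, even though the hydrogen-bond acceptor of furan-3-yl is absent from phenyl. Nothing among the data gives a measured reason for this outcome or bears on how the two groups act at this position.

The compounds shown leave open whether this carbon would tolerate something other than a single aromatic ring, such as a methyl group or a saturated cyclohexyl ring, and whether a phenyl ring carrying an amine or a carboxylic acid would shift the number beyond the scatter. They also leave open which of the several differences separates compound 2 from compound 1 and compound 3, as no single change links compound 2 to either of them.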